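A Methyl Added to the Fused Ring of Compound 2

This account rests on a few compounds, and the source may have more. Where it says the series, first, only, none or still open, it means among the compounds named here.

Going by the values given here, compound 2 `Clc1ccc(-c2nn(-c3ccccc3)cc2-c2nc3ccccc3[nH]2)cc1` is the weaker of the two measured members of this small set: in a functional assay on MCF7 cells (Homo sapiens) for antiproliferative activity, read by MTT assay, with a stated time of 48 h (on this read-out higher numbers stand for weaker inhibition and lower numbers for stronger inhibition), compound 2 gives 3030 nM, the highest of the two numbers recorded. Its nearest neighbour is compound 1 `Cc1ccc2[nH]c(-c3cn(-c4ccccc4)nc3-c3ccc(F)cc3)nc2c1`, which in this assay gives 1120 nM, a lower number by a margin that lies beyond the usual scatter of repeated runs. Among the compounds with values here, compound 1 differs from compound 2 in two places at once, so no single step between the two can be read off.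

Compound 3 `Cc1ccc2[nH]c(-c3cn(-c4ccccc4)nc3-c3ccc(Cl)cc3)nc2c1` is the next compound to be examined. It takes one defined step away from compound 2: methyl in place of hydrogen on an aromatic carbon. Because compound 1, which carries the same methyl on the fused ring, gives 1120 nM, a modest step toward a lower number is expected, and the estimated step of a 1.7-fold lower number from compound 2 to compound 3 (0.23 log units; within the scatter) is of a size near the edge of the scatter. For compound 3 the value in this assay is estimated at 1800 nM, within a range from 700 nM to 4500 nM.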

Compound 3, half-maximal inhibitory concentration: 8230 nM
The estimate for compound 3 lay 4.6-fold (0.66 log units) below the measured number; measured number above the stated range.
By their numbers in this assay, from the lowest: compound 1; then compound 2; then compound 3.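

In this assay, methyl in place of hydrogen on an aromatic carbon of the fused system does not move the number down, as compound 1 had suggested, but gives a 2.7-fold higher number from compound 2 to compound 3 (0.43 log units; beyond the scatter) and so goes with weaker inhibition in this chloro-bearing pair. With the methyl held constant, the halogen also counts: chloro in place of fluoro on an aromatic carbon gives a 7.3-fold higher number from compound 1 to compound 3 (0.87 log units; beyond the scatter) and likewise goes with weaker inhibition. The methyl step is therefore read only alongside chloro, and the halogen step only alongside methyl.

From the compounds shown here alone, whether methyl would give a step of the same direction alongside fluoro stays open, as does what a methoxy group or an amine would do on the same aromatic carbon. Nothing given here bears on what lies behind either step.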